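Triazole nitrogen substituent: cyclobutyl to methylpyrimidinyl

The compounds below may be only part of what the source reports. "The series", "measured", "known", "first", "only" and "open" are said of these compounds alone.

Among the measured compounds shown here, compound 2 `CN1C(=S)[C@@H](NC(=O)c2nc(Cc3ccccc3)n(C3CCC3)n2)COc2ccccc21` gives 181 nM in a functional assay on HT-29 cells (Homo sapiens) for inhibition, read by luminescence and CellTiter-Glo, with a stated time of 24 h (a lower number here means that less compound is needed, a higher number that more compound is needed for the effect), the lower of the two numbers measured so far, with compound 1 `CN1C(=S)[C@@H](NC(=O)c2nc(Cc3ccccc3)n(CCCO)n2)COc2ccccc21` giving 209 nM in this assay; the step of a 1.2-fold lower number from compound 1 to compound 2 (0.06 log units; within the scatter) stays within the scatter. Compound 3 `CN1C(=S)[C@@H](NC(=O)c2nc(Cc3ccccc3)n(C3CCN(C(=O)OC(C)(C)C)CC3)n2)COc2ccccc21` returns only a limit, > 10000 nM, and the limit of > 10000 nM in this assay, at which 1 of the 3 values shown sits, marks where it sits. Compound 4 `Cc1cnc(-n2nc(C(=O)N[C@H]3COc4ccccc4N(C)C3=S)nc2Cc2ccccc2)nc1` differs from compound 2 by 5-methylpyrimidin-2-yl in place of cyclobutyl on an aromatic nitrogen. For the measured compounds named here, only the step from compound 1 to compound 2 bears on this position, and it is flat; the limit of compound 3 shows the same position tolerating no measurable effect with a large group. The entering group is larger than cyclobutyl yet far smaller than the group of compound 3, so a modest rise is expected. Compound 4 is estimated at 400 nM (range 120 nM to 1500 nM). The expected step is a 2.2-fold higher number from compound 2 to compound 4 (0.34 log units; beyond the scatter).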

Compound 4, half-maximal effective concentration: 1950 nM
Compound 4: middle estimate off by 4.9-fold (0.69 log units), on the low side, and the stated range ends below it.
By their numbers in this assay, from the lowest: compounds 2 and 1 (each within the scatter of the next); then compound 4. At a limit, above all of these: compound 3.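

The aromatic nitrogen is not indifferent to its substituent: in this assay, 5-methylpyrimidin-2-yl gives an 11-fold higher number from compound 2 to compound 4 (1.03 log units; beyond the scatter) and a 9.3-fold higher number from compound 1 to compound 4 (0.97 log units; beyond the scatter), whereas cyclobutyl and 3-hydroxypropyl lie within the scatter of each other. Among the compounds shown here, a clear loss therefore appears here with a group much smaller than the one in compound 3. Compound 3 remains a limit, not a number: the limit of > 10000 nM in this assay, at which 1 of the 4 values shown sits.

A plain phenyl group on this nitrogen would help separate the contribution of the aromatic ring from that of its ring nitrogens. Also open, on these data alone, is how a free piperidin-4-yl amine would compare with the protected group of compound 3.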